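A Methyl on the Aromatic Ring, in Two Related Series

The compounds below may be only part of what the source reports. "The series", "measured", "known", "first", "only" and "open" are said of these compounds alone.

In a functional assay on the whole organism for antagonist activity, with Mus musculus as the target (on this read-out lower numbers stand for an effect already at smaller amounts and higher numbers for an effect only at larger amounts of compound), compound 1 `CC(=O)N(C)CC#CCn1ccnc1` gives only a limit, > 100 mg/kg. Compound 2 `CC(=O)N(C)CC#CCn1cncc1C` gives 6.6 mg/kg. The change between them is methyl in place of hydrogen on an aromatic carbon and it produced an at least 15-fold lower number from compound 1 to compound 2 (1.18 log units; beyond the scatter).

Compound 3 `O=C1OCCN1CC#CCn1ccnc1` also gives only a limit in this assay, > 100 mg/kg. The difference between the cores of compound 1 and compound 3 is not broken down here. Compound 4 `Cc1cncn1CC#CCN1CCOC1=O` carries the same kind of change as compound 2, namely (methyl in place of hydrogen on an aromatic carbon); the surroundings are described as a large group rather than a group of 9 heavy atoms. Two of the three results sit at the limit of > 100 mg/kg in this assay, at which 2 of the 3 values shown sit.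

Resting on an at least 15-fold lower number from compound 1 to compound 2 (1.18 log units; beyond the scatter), a step of about an at least 5.0-fold lower number from compound 3 to compound 4 (0.69 log units; beyond the scatter) is expected from the same kind of change. Compound 4 is therefore estimated at 20 mg/kg, between 5 mg/kg and 100 mg/kg.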

Compound 4, dose for half-maximal effect: 37 mg/kg
The estimate for compound 4 lay 1.9-fold (0.27 log units) below the measured number; measured number inside the range.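

Carried to a second core, methyl in place of hydrogen on an aromatic carbon again gives an at least 2.7-fold lower number from compound 3 to compound 4 (0.43 log units; beyond the scatter) in this assay, so the direction of the step carries over. Two cores are all this rests on, so it shows agreement in this pair and no general rule for the series. Whether the step is equally large on both cores stays unsettled: the same change on two cores in this assay, an at least 15-fold lower number (1.18 log units; beyond the scatter) from compound 1 to compound 2 and an at least 2.7-fold lower number (0.43 log units; beyond the scatter) from compound 3 to compound 4; the limit leaves it open whether they differ

The compounds shown leave open whether ethyl, trifluoromethyl or a longer chain on the same aromatic carbon would act as methyl does. As far as these compounds go, the real numbers for compound 1 and compound 3 also stay open, since each gives only a limit.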